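The source may report more compounds than this note shows. Statements on the series, on what has been measured and on what is new or still open speak of the compounds shown alone.

Measured compounds in an assay on HEK293 cells for inhibition of transient receptor potential cation channel subfamily V member 1 (Homo sapiens), read by FLIPR; a higher number here means a weaker inhibitor, a lower number a stronger inhibitor:

Compound 1, `Cc1ccc(N2CCN(C(=O)Nc3ccc(C(F)(F)F)cc3)CC2)nn1`, compound 1 gives > 10000 nM, which is a limit of the assay and not a number.
Compound 2, `Cc1ccc(N2CCN(C(=O)Nc3ccc(OC(F)(F)F)cc3)CC2)nn1`, compound 2 gives > 10000 nM, likewise a limit.
Compound 3, `O=C(Nc1ccc(OC(F)(F)F)cc1)N1CCN(c2ccc(-c3ccccc3)nn2)CC1`, compound 3 gives > 10000 nM, again a limit.

Compound 2 therefore stands at a limit of this assay; the two other values shown are limits as well, so no ordering among the three can be read. The step from compound 1 to compound 2 is a step that the two limits leave unreadable from compound 1 to compound 2 and the step from compound 2 to compound 3 is a step that the two limits leave unreadable from compound 2 to compound 3; neither has a readable size.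

Compound 4, `O=C(Nc1ccc(OC(F)(F)F)cc1)N1CCN(c2nncc3ccccc23)CC1`, is not yet measured. It differs from compound 2 by a group of 10 heavy atoms (8 carbon, 2 nitrogen; one six-membered aromatic ring of carbon only, one six-membered aromatic ring with 2 hetero atoms) in place of a group of 7 heavy atoms (5 carbon, 2 nitrogen; one six-membered aromatic ring with 2 hetero atoms), on an amine nitrogen in a ring.

Among the measured compounds shown here, the only bearing on this change comes from the limit of > 10000 nM in this assay, at which 3 of the 3 values shown sit: every value shown sits at the limit, and the two steps around compound 2 are unreadable. For the measured compounds named here, no measured step reports a change in this assay beyond the scatter, so no direction can be supported; the expectation is that compound 4 again sits near the limit. The step from compound 2 to compound 4 is expected to be a step that the limit leaves unreadable from compound 2 to compound 4. Compound 4 is estimated at 15000 nM, in the range 4000 nM to 60000 nM.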

Compound 4, half-maximal inhibitory concentration: > 10000 nM
Compound 4 was reported as a limit; the forecaster's own chance of this, stated with the estimate: 75%; the middle value lies beyond the limit too.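

In this assay compound 4 gives > 10000 nM, a limit of the assay and not a number. Among the compounds shown here, compound 2 also sits at a limit, so no step between compound 2 and compound 4 can be read. The compounds shown leave open how far any of them lies past the limit, and which change, if any, would bring a measurable value in this assay.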